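Trading a Methylphenyl for a Trifluoromethylphenyl Group

The compounds below may be only part of what the source reports. "The series", "measured", "known", "first", "only" and "open" are said of these compounds alone.

Compound 1, `Cc1cc(NC(=O)Cn2nnc(-c3ccccn3)n2)n(C2CCCCC2)n1`: 81%
Compound 2, `Cc1cccc(-c2nnn(CC(=O)Nc3cc(C)nn3C3CCCCC3)n2)c1`: 93%

In an assay on HEK293 cells for activation of Kir3.1/Kir3.2 (Homo sapiens), read by thallium flux (a lower number here means a smaller maximal response, a higher number a larger maximal response), compound 2 gives 93%, the highest of the two numbers measured. Within the data shown here, its nearest neighbour, compound 1, gives 81%, and the single measured step, a number 12 percentage points higher from compound 1 to compound 2 (beyond the scatter), separates them.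

Compound 3, `Cc1cc(NC(=O)Cn2nnc(-c3ccc(C(F)(F)F)cc3)n2)n(C2CCCCC2)n1`, is the next candidate. It differs from compound 2 in one place: 4-(trifluoromethyl)phenyl in place of 3-methylphenyl on an aromatic carbon. Among the measured compounds shown here, the only step on record, a number 12 percentage points higher from compound 1 to compound 2 (beyond the scatter), touches the same aromatic carbon but exchanges a different pair of groups, so it bears on the present change only loosely. With both groups entering and leaving being six-membered carbon rings and with no donor or acceptor count changing, no step beyond the scatter is expected in this assay.

Compound 3 is therefore estimated at 90%, with a range from 75% to 100%. The expected step is a number 3 percentage points lower from compound 2 to compound 3 (within the scatter), within the usual scatter.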

Compound 3, largest response reached (Emax), in percent of the reference or control that the assay uses: 94%
Beside the measured number, compound 3's estimate is 4 percentage points below it; the range from low to high includes it.
By their numbers in this assay, from the lowest: compound 1; then compounds 2 and 3 (each within the scatter of the next).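

At this aromatic carbon, in this assay, the exchange of 3-methylphenyl for 4-(trifluoromethyl)phenyl gives a number 1 percentage points higher from compound 2 to compound 3 (within the scatter), so the two groups cannot be told apart by this read-out. Set against pyridin-2-yl, 4-(trifluoromethyl)phenyl gives a number 13 percentage points higher from compound 1 to compound 3 (beyond the scatter), in the same direction as a number 12 percentage points higher from compound 1 to compound 2 (beyond the scatter), and so among the three compounds both carbon-only aromatic rings stand apart from pyridin-2-yl, with none going against this. No measurement offered here explains this pattern.

The compounds shown leave open whether the methyl or trifluoromethyl group, or its place on the phenyl ring, matters at all, since 3-methylphenyl and 4-(trifluoromethyl)phenyl differ in both. They also leave open how this position responds to a non-aromatic group such as cyclohexyl, or to a phenyl ring carrying an amine or a carboxylic acid.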